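Chloro for methoxy on a methylsulfanyl aniline core

A few compounds are considered here, and "the series" means these few. Any claim that something is new, unique, unknown or untested is made for them only; others in the source may bear on it.

Compounds measured:
compound 1, `Cc1ccc(S(C)(=O)=O)c(NCC2=NCCN2)c1`, 91%
compound 2, `CSc1cc(F)ccc1NCC1=NCCN1`, 78%
compound 3, `COc1ccc(SC)c(NCC2=NCCN2)c1`, 92%

In a functional assay for agonist activity at Alpha-1B adrenergic receptor (Homo sapiens) (a higher number here means a larger maximal response, a lower number a smaller maximal response), compound 3 gives 92%, the highest of the three numbers; compound 1 with 91% sits within the scatter of it, while compound 2 with 78% lies beyond the scatter below it. Compound 4, `CSc1ccc(Cl)cc1NCC1=NCCN1`, is not yet measured. It differs from compound 3 by chloro in place of methoxy on an aromatic carbon. Going by the values given here, no measured pair shows this change, so its size is unknown. Among the compounds with values here, compound 2, the only other halogen-bearing member, gives the lowest number, which suggests a modest decrease. The step of a number 10 percentage points lower from compound 3 to compound 4 (within the scatter) is the author's expectation. Compound 4 is estimated at 82%, between 65% and 96%.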

Compound 4, largest response reached (reported as maximum), in percent of the reference or control that the assay uses: 103%
Compound 4: the middle estimate sits 21 percentage points below what was measured, and the stated range ends below it.
By their numbers in this assay, from the lowest: compound 2; then compounds 1 and 3 (each within the scatter of the next); then compound 4.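

In this assay, going by these compounds alone, chloro in place of methoxy on this aromatic carbon, para to the methylsulfanyl group, gives a number 11 percentage points higher from compound 3 to compound 4 (beyond the scatter) and is the first single-place change in the set. It shows that this carbon does not need methoxy for a high maximal response, and that chloro here raises the response beyond the scatter. No measurement shown accounts for this step. On these data alone, whether chloro itself matters or only the loss of methoxy stays open, and bromo, an unsubstituted carbon or an amine at this position would be needed to separate the two.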